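The source may report more compounds than this note shows. Statements on the series, on what has been measured and on what is new or still open speak of the compounds shown alone.

Working notes on the series. Compound 1 `O=C(N/N=C\c1cn(Cc2ccc(Cl)cc2)c2cc(F)ccc12)c1c[nH]c2ccccc12` in a functional assay on LNCaP cells (Homo sapiens) for cytotoxicity (a lower number here means a stronger inhibitor, a higher number a weaker inhibitor), gives 55200 nM. Compound 2 `Cn1cc(C(=O)N/N=C\c2cn(Cc3ccc(Cl)cc3)c3cc(F)ccc23)c2ccccc21` carries a methyl in place of hydrogen on an aromatic nitrogen; in this assay compound 2 reports only a limit, > 100000 nM. The step of an at least 1.8-fold higher number from compound 1 to compound 2 (0.25 log units; that floor lies within the scatter) is therefore bounded by the limit of > 100000 nM in this assay, at which 2 of the 3 values shown sit, and cannot be sized further. Compound 3 `COc1ccc(Cn2cc(/C=N\NC(=O)c3c[nH]c4ccc(Br)cc34)c3ccc(F)cc32)cc1` in this assay also reports only a limit, > 100000 nM. On the numbers shown, compound 3 thus stands at the limit described by the limit of > 100000 nM in this assay, at which 2 of the 3 values shown sit, with no number of its own to set against compound 1. Compound 4 `O=C(N/N=C\c1cn(Cc2ccc(Cl)cc2)c2cc(F)ccc12)c1c[nH]c2ccc(Br)cc12` is not yet measured and differs from compound 3 by chloro in place of methoxy on an aromatic carbon. Going by the values given here, no measured step covers this change: the single sized step concerns the aromatic nitrogen, not the benzyl substituent, and the limit on compound 3 leaves the starting point open. Compound 4 is expected to stand at 80000 nM, with a range from 30000 nM to 250000 nM. Among the compounds with values here, the expected step of an at least 1.2-fold lower number from compound 3 to compound 4 (0.09 log units; that floor lies within the scatter) rests on compound 1, whose value 55200 nM is the only number and belongs to the same 4-chlorobenzyl group.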

Compound 4, half-maximal inhibitory concentration: 24800 nM
The estimate for compound 4 lay 3.2-fold (0.51 log units) above the measured number; the whole stated range lies above it.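

In this assay, going by these compounds alone, the benzyl substituent is the first change here to show an effect beyond the scatter, with an at least 4.0-fold lower number from compound 3 to compound 4 (0.60 log units; beyond the scatter), for chloro in place of methoxy. Bromo in place of hydrogen on an aromatic carbon also counts, with a 2.2-fold lower number from compound 1 to compound 4 (0.35 log units; beyond the scatter), and this is the first step in the series with a number at both ends. The change of group on the carbonyl carbon gives an at least 4.0-fold lower number from compound 2 to compound 4 (0.60 log units; beyond the scatter), and this step and the chloro step are floors only, each with one end resting on a limit: the limit of > 100000 nM in this assay, at which 2 of the 4 values shown sit.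

The compounds shown leave open whether the chloro advantage holds without the bromo, and whether a 4-fluorobenzyl or 4-trifluoromethylbenzyl group would go further. They also leave open what an amine or a carboxylic acid at that position would do.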